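Cytotoxicity at the assay limit across three compounds

The compounds below may be only part of what the source reports. "The series", "measured", "known", "first", "only" and "open" are said of these compounds alone.

Compound 1, `CC(C)N(Cc1cccc(OCCCCCC(=O)O)c1)C(=O)c1ccc(-c2cccc(N(C)C)c2)cc1`, gives in an ADME assay on HEK293 cells (Homo sapiens) for cytotoxicity, read by CellTiter-Glo and resazurin assay, with a stated time of 72 h (on this read-out lower numbers stand for an effect already at smaller amounts and higher numbers for an effect only at larger amounts of compound), only a limit, > 26000 nM.
Compound 2, `CC(C)N(Cc1cccc(OCCCCCC(=O)O)c1)C(=O)c1ccccc1`, gives in this assay only a limit, > 26000 nM.
Compound 3, `CC(C)N(Cc1cccc(OCCCCCC(=O)O)c1)C(=O)c1ccc(-c2ccc3[nH]ccc3c2)cc1`, gives in this assay only a limit, > 26000 nM.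

Compound 3 therefore stands where its two companions stand: at the edge of what this assay can report, with no number of its own. The same holds for every value shown, as the limit of > 26000 nM in this assay, at which 3 of the 3 values shown sit, records. Because of this the three steps among the measured compounds cannot be read: a step that the two limits leave unreadable from compound 1 to compound 2, a step that the two limits leave unreadable from compound 1 to compound 3 and a step that the two limits leave unreadable from compound 2 to compound 3 each connect two limits and give no size.

Compound 4, `CC(C)N(Cc1cccc(OCCCCCC(=O)O)c1)C(=O)c1ccc(-c2cccc(OC(F)(F)F)c2)cc1`, differs from compound 3 in one place: 3-(trifluoromethoxy)phenyl in place of 1H-indol-5-yl on an aromatic carbon. Among the compounds with values here, the steps that bear on this change are the three just named, and none of them yields a readable size, so no direction can be drawn from them. What they do show is that every variation at this aromatic carbon so far has left the read-out at its limit. Compound 4 is therefore expected to show no step beyond the scatter in this assay, that is a number no higher from compound 3 to compound 4 (the limit leaves the size open), and most likely to return a limit again. The estimate for compound 4 is 26000 nM, with a range from 10000 nM to 60000 nM.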

Compound 4, half-maximal effective concentration: > 26000 nM
Compound 4 was reported as a limit (the forecaster's own chance of this, stated with the estimate: 85%); the middle value lies on the limit itself.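

Within the data shown here, compound 4 is also reported only as a limit, so no step linking it to compound 1, compound 2 or compound 3 can be read in this assay because all four values rest on the same limit: the limit of > 26000 nM in this assay, at which 4 of the 4 values shown sit.

The compounds shown leave open at what concentration, if any, each would reach a half-maximal effect on these cells.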